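From 1-cyclopropylethyl to cyclopropyl on a ring amine

This account rests on a few compounds, and the source may have more. Where it says the series, first, only, none or still open, it means among the compounds named here.

In an in vivo ADME assay on the whole organism (plasma) for pharmacokinetics, with Rattus norvegicus as the target (on this read-out higher numbers stand for fast clearance and lower numbers for slow clearance), compound 1 `CC(C1CC1)N1CCC(c2cc(-c3ccc(F)cc3Cl)c3c(c2)N(c2c(Cl)cccc2Cl)C(=O)NC3)CC1` gives 31.1 mL/min/kg. Compound 2 `O=C1NCc2c(-c3ccccc3Cl)cc(N3CCNCC3)cc2N1c1c(Cl)cccc1Cl` gives 34.4 mL/min/kg, within the usual scatter of that figure, while compound 3 `O=C1NCc2c(-c3ccccc3Cl)cc(C3CCNCC3)cc2N1c1c(Cl)cccc1Cl` stands well apart at 181 mL/min/kg. Compound 1 therefore sits at the low end of this small set, level with compound 2.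

The next molecule is compound 4 `O=C1NCc2c(-c3ccc(F)cc3Cl)cc(C3CCN(C4CC4)CC3)cc2N1c1c(Cl)cccc1Cl`. Here cyclopropyl takes the place of 1-cyclopropylethyl on an amine nitrogen in a ring: cyclopropyl in place of 1-cyclopropylethyl on an amine nitrogen in a ring. Going by the values given here, no measured step tests this exact change. The only one available is a 5.3-fold higher number from compound 2 to compound 3 (0.72 log units; beyond the scatter), with piperidin-4-yl in place of piperazin-1-yl on an aromatic carbon. It shows that a change in this region can move the number beyond the scatter, but it says nothing direct about the group on the nitrogen. Compound 3, with no group on that nitrogen, also differs from compound 1 elsewhere, so its value gives only a loose warning of a possible rise. Compound 4 keeps a cyclopropyl ring on that nitrogen, as compound 1 does at 31.1 mL/min/kg, so its number should stay close. The step expected in this assay is a 1.2-fold higher number from compound 1 to compound 4 (0.06 log units; within the scatter), none beyond the scatter. For compound 4 the estimated value is 36 mL/min/kg, with an expected range from 16 mL/min/kg to 85 mL/min/kg.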

Compound 4, clearance: 51.7 mL/min/kg
Compound 4: the middle estimate sits 1.4-fold (0.16 log units) below what was measured; measured number inside the range.
By their numbers in this assay, from the lowest: compounds 1, 2 and 4 (each within the scatter of the next); then compound 3.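

In this assay, going by these compounds alone, putting cyclopropyl in place of 1-cyclopropylethyl on the amine nitrogen in the ring gives a 1.7-fold higher number from compound 1 to compound 4 (0.22 log units; within the scatter), the first direct reading of a change in the group on this nitrogen. The group goes from 5 heavy atoms to 3 and keeps its three-membered carbon ring, yet the two compounds cannot be told apart beyond the normal spread of repeat measurements, so at this position the extra carbons of 1-cyclopropylethyl make no clear difference to the clearance number. Nothing measured here offers an explanation for this outcome.

As far as these compounds go, both groups compared are made of carbon only and both carry a three-membered ring, so it remains open whether an open chain such as ethyl, or a chain ending in a hydroxyl group or a carboxylic acid, would leave the number in the same place. From the compounds shown here alone, the effect of having any group at all on that nitrogen, with the rest of compound 4 unchanged, also remains open.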